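The compounds below may be only part of what the source reports. "The series", "measured", "known", "first", "only" and "open" are said of these compounds alone.

Compound 1 `CCCCCC/C=C/C[C@H]1C[C@@H]([C@@H](O)c2ccccc2)CO[C@@H]1c1ccccc1` gives 7400 nM
Compound 2 `O[C@@H](c1ccccc1)[C@H]1CO[C@H](c2ccccc2)[C@@H](C/C=C/C2CCCC2)C1` gives 9330 nM

In a functional assay on HeLa cells (Homo sapiens) for cytotoxicity, read by WST assay, with a stated time of 48 h (a higher number here means a weaker inhibitor, a lower number a stronger inhibitor), compound 2 stands at 9330 nM and cannot be told apart from compound 1 . Compound 3 `Oc1cccc(/C=C/C[C@H]2C[C@@H]([C@@H](O)c3ccccc3)CO[C@@H]2c2ccccc2)c1` carries 3-hydroxyphenyl in place of cyclopentyl on a double-bonded chain carbon bound to a double-bonded chain carbon. Within the data shown here, only one measured step bears on this place, a 1.3-fold higher number from compound 1 to compound 2 (0.10 log units; within the scatter), with cyclopentyl in place of hexyl. That step gives no reason to expect a change beyond the scatter, although no measured compound has 3-hydroxyphenyl there, so the range stays wide. The expected step is a 1.3-fold lower number from compound 2 to compound 3 (0.12 log units; within the scatter). Compound 3 is estimated at 7000 nM, with an expected range of 2500 nM to 18000 nM.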

Compound 3, half-maximal inhibitory concentration: 18600 nM
Estimate against measurement, compound 3: 2.7-fold (0.42 log units) below; measured number above the stated range.
By their numbers in this assay, from the lowest: compounds 1, 2 and 3 (each within the scatter of the next, the first and the last beyond it).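

In this assay, among these compounds, 3-hydroxyphenyl in place of hexyl on a double-bonded chain carbon bound to a double-bonded chain carbon is the first change at this position to pass the scatter, though only modestly, with a 2.5-fold higher number from compound 1 to compound 3 (0.40 log units; beyond the scatter). In place of cyclopentyl, the same group gives a 2.0-fold higher number from compound 2 to compound 3 (0.30 log units; within the scatter), so it cannot be separated from cyclopentyl. Nothing available explains this result. The compounds shown leave open whether the ring or its hydroxyl carries the step, and how an unsubstituted phenyl, an amine or a carboxylic acid would read here.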